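A few compounds are considered here, and "the series" means these few. Any claim that something is new, unique, unknown or untested is made for them only; others in the source may bear on it.

Measured in a functional assay on HepG2 cells (Homo sapiens) for cytotoxicity, read by MTT assay, with a stated time of 72 h; on this read-out lower numbers stand for stronger inhibition and higher numbers for weaker inhibition: compound 1 `COc1c(OCCCCN2CCN(C)CC2)cc(O)c2c(=O)cc(-c3ccc(C)cc3)oc12` gives 1000 nM; compound 2 `COc1c(OCCCCN2CCN(C)CC2)cc(O)c2c(=O)cc(-c3ccc(F)cc3Br)oc12` gives 2130 nM; compound 3 `CN(C)CCCOc1c(OCc2ccccc2)cc(O)c2c(=O)cc(-c3ccccc3)oc12` gives 4950 nM.

Compound 3 carries the highest number of the three, beyond the scatter against both other compounds. The next compound, compound 4 `CN1CCN(CCCCOc2c(OCc3ccccc3)cc(O)c3c(=O)cc(-c4ccccc4)oc23)CC1`, differs from it in one place: (4-methylpiperazin-1-yl)methyl in place of dimethylamino on a saturated chain carbon, three bonds along the chain from an oxygen on an aromatic ring. Among the measured compounds shown here, the only step measured so far, a 2.1-fold higher number from compound 1 to compound 2 (0.33 log units; beyond the scatter), concerns the aryl group and not the chain amine, so no measured step bears on this change. Compounds 1 and 2, which carry the same chain amine as compound 4, show lower numbers than compound 3 but differ from it in two further places. A modest lowering at most is therefore expected for compound 4, a 1.4-fold lower number from compound 3 to compound 4 (0.15 log units; within the scatter). For compound 4 in this assay the estimate is 3500 nM, range 1200 nM to 10000 nM.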

Compound 4, half-maximal inhibitory concentration: 1500 nM
Estimate against measurement, compound 4: 2.3-fold (0.37 log units) above; the measured number falls inside the stated range.
By their numbers in this assay, from the lowest: compounds 1, 4 and 2 (each within the scatter of the next, the first and the last beyond it); then compound 3.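

In this assay the chain end responds to change: 4-(4-methylpiperazin-1-yl)butyl in place of 3-(dimethylamino)propyl gives a 3.3-fold lower number from compound 3 to compound 4 (0.52 log units; beyond the scatter) on the core of compound 3. Among the compounds shown here, this is the first step read at the chain, and it swaps the amine and lengthens the chain in a single change. No measurement shown explains the step.
The compounds shown leave open whether the piperazine ring or the longer chain carries the step. A 4-(dimethylamino)butyl chain or a 3-(4-methylpiperazin-1-yl)propyl chain on the same core would separate the two.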